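Methyl for Iodo on a Pair of Cytotoxicity Limits

The compounds below may be only part of what the source reports. "The series", "measured", "known", "first", "only" and "open" are said of these compounds alone.

Compound 1 `OCc1cn(Cc2cccc(Cl)c2)c2ccccc12` is tested in an ADME assay on T29 cells (Homo sapiens) for cytotoxicity, read by sulforhodamine B assay, with a stated time of 3 days (on this read-out lower numbers stand for stronger inhibition and higher numbers for weaker inhibition), where compound 1 gives only a limit, > 31600 nM. Compound 2 `OCc1cn(Cc2cccc(I)c2)c2ccccc12` likewise gives only a limit in this assay, > 31600 nM. The step that the two limits leave unreadable from compound 1 to compound 2 therefore cannot be read, and both values sit at the limit of > 31600 nM in this assay, at which 2 of the 2 values shown sit. Compound 3 `Cc1cccc(Cn2cc(CO)c3ccccc32)c1` differs from compound 2 by methyl in place of iodo on an aromatic carbon. Within the data shown here, no measured step in this assay gives a readable size, so compound 3 is expected to remain near the limit, with an estimated step that the limit leaves unreadable from compound 2 to compound 3. Compound 3 is estimated at 45000 nM, within 20000 nM to 120000 nM.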

Compound 3, half-maximal inhibitory concentration: > 31600 nM
Compound 3: a limit, no number; the forecaster's own chance of this, stated with the estimate: 85%; the middle value does not contradict the limit.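

Among these compounds, compound 3 too gives only a limit of > 31600 nM and so no step among compound 1, compound 2 and compound 3 can be read. Whether chloro, iodo and methyl differ at all in this assay stays open, with every value at one limit: the limit of > 31600 nM in this assay, at which 3 of the 3 values shown sit.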